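The source may hold more compounds than are shown below. What is called first, only, known or untested is meant among the compounds shown, and "the series" means these compounds.

Working notes on the series. Compound 1 `CC1(COc2ccc(-c3ccc(F)cc3)cc2)Cn2cc([N+](=O)[O-])nc2O1` is followed here into compound 3 `C[C@@]1(COc2ccc(-c3ccc(F)cc3)cc2)Cn2cc([N+](=O)[O-])nc2O1`, which differs only in stereochemical drawing. In an ADME assay on MRC5 cells (Homo sapiens) for cytotoxicity, read by fluorescence, with a stated time of 72 h (on this read-out lower numbers stand for stronger inhibition and higher numbers for weaker inhibition), compound 1 gives only a limit, > 64000 nM. Going by the values given here, the one other measured member, compound 2 `O=[N+]([O-])c1cn2c(n1)OC(COc1ccc(-c3ccc(F)cc3)cc1)C2`, behaves alike. In this assay compound 2 gives a limit too, > 64000 nM. Among the compounds with values here, the sole measured step in the set, a step that the two limits leave unreadable from compound 1 to compound 2, is consequently a step that the two limits leave unreadable. Both values sit at the limit of > 64000 nM in this assay, at which 2 of the 2 values shown sit. Compound 1 therefore stands at the limit of this assay and nowhere else on the numbers shown.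

The change from compound 1 to compound 3 is the two compounds have the same atoms and bonds; at least one stereo element is drawn with a configuration in one of them and without one in the other: 1 of 1 stereo elements differ; a stereocentre at a saturated ring carbon is drawn without a configuration in compound 1 and S in compound 3. Neither atoms nor bonds move; only the drawn configuration at the saturated ring carbon is fixed. Within the data shown here, the step from compound 1 to compound 2 touches the same saturated ring carbon through its methyl, but its size is not readable, and no measured step here separates two stereoisomers. A step in this assay beyond the scatter is not expected for compound 3. The expected step is a number no higher from compound 1 to compound 3 (the limit leaves the size open). Compound 3 is expected to give 64000 nM in this assay, within a range from 32000 nM to 128000 nM, and most probably once more only a limit.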

Compound 3, half-maximal inhibitory concentration: > 64000 nM
Compound 3 gave a limit, no number; the forecaster's own chance of this, stated with the estimate: 85%; the middle value lies on the limit itself.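

No new step can be read between compound 1 and compound 3 in this assay, where each gives only a limit and no number: the limit of > 64000 nM in this assay, at which 3 of the 3 values shown sit. The compounds shown leave open whether the configuration drawn at the saturated ring carbon has any effect on this read-out, since none of the three gives a number.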